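A few compounds are considered here, and "the series" means these few. Any claim that something is new, unique, unknown or untested is made for them only; others in the source may bear on it.

- Compound 1 `Cn1cc(C2CC(c3ccc(F)cc3)=NN2C(=O)c2cccnc2)c2cc(Br)ccc21`: 480 nM
- Compound 2 `Cn1cc(C2CC(c3ccc(Br)cc3)=NN2C(=O)c2cccnc2)c2cc(Br)ccc21`: 6910 nM
- Compound 3 `COc1ccc(C2=NN(C(=O)c3cccnc3)C(c3cn(C)c4ccc(Br)cc34)C2)cc1`: 540 nM
- Compound 4 `COc1ccc(C2=NN(C(=O)c3cccnc3)C(c3cn(C)c4ccc(Br)cc34)C2)cc1OC`: not yet measured

In a functional assay on HepG2 cells (Homo sapiens) for inhibition, read by MTT assay, with a stated time of 48 h (on this read-out lower numbers stand for stronger inhibition of growth and higher numbers for weaker inhibition of growth), compound 3 gives 540 nM. It sits level with compound 1, as a 1.1-fold higher number from compound 1 to compound 3 (0.05 log units; within the scatter) shows, while compound 2 lies well apart, as a 13-fold lower number from compound 2 to compound 3 (1.11 log units; beyond the scatter) shows.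

Compound 4 turns the 4-methoxyphenyl of compound 3 into 3,4-dimethoxyphenyl: methoxy in place of hydrogen on an aromatic carbon. This is methoxy in place of hydrogen on an aromatic carbon, ortho to a methoxy group.

Within the data shown here, no measured step adds a second group to this ring. Among the measured compounds shown here, the nearest evidence comes from swaps of the single group on it. One swap barely registers, a 1.1-fold higher number from compound 1 to compound 3 (0.05 log units; within the scatter), whereas the bromo swap is large, a 14-fold higher number from compound 1 to compound 2 (1.16 log units; beyond the scatter). A large jump therefore cannot be excluded, but methoxy already gave a value close to that of fluoro, so a modest change seems likelier.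

The expected step is small and slightly upward, a 1.5-fold higher number from compound 3 to compound 4 (0.17 log units; within the scatter), with nothing beyond the scatter anticipated. Compound 4 is estimated at 800 nM, with an expected range of 200 nM to 3500 nM.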

Compound 4, concentration for 50% growth inhibition: 2450 nM
Compound 4: middle estimate off by 3.1-fold (0.49 log units), on the low side; the measured number falls inside the stated range.
By their numbers in this assay, from the lowest: compounds 1 and 3 (each within the scatter of the next); then compound 4; then compound 2.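

In this assay, among these compounds, adding a second group to this ring has a clear effect, although swapping fluoro for methoxy as the single group left compound 1 and compound 3 level: the added methoxy gives a 4.5-fold higher number from compound 3 to compound 4 (0.66 log units; beyond the scatter). The 3,4-dimethoxyphenyl ring also separates compound 4 from both other analogues, with a 5.1-fold higher number from compound 1 to compound 4 (0.71 log units; beyond the scatter) and a 2.8-fold lower number from compound 2 to compound 4 (0.45 log units; beyond the scatter), so its number falls in the gap left by the 4-fluorophenyl and 4-bromophenyl compounds. Nothing measured here explains why the added methoxy weakens growth inhibition.

As far as these compounds go, it remains open whether this weakening is specific to methoxy or would follow any added group ortho to the first methoxy. A hydroxy group, an amine or a chloro atom on that same aromatic carbon would help separate these two readings.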